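Stretching the Chain of Compound 2 Further

This account rests on a few compounds, and the source may have more. Where it says the series, first, only, none or still open, it means among the compounds named here.

In a functional assay on MCF7 cells (Homo sapiens) for antiproliferative activity, read by MTT assay, with a stated time of 48 h (on this read-out lower numbers stand for stronger inhibition and higher numbers for weaker inhibition), compound 1 `COc1cc2ncnc(Nc3cccc(Br)c3)c2cc1OCCC(=O)NO` reads > 100000 nM, which is a limit of the assay and not a number. Among the measured compounds shown here, compound 2 `COc1cc2ncnc(Nc3cccc(Br)c3)c2cc1OCCCC(=O)NO` gives 68400 nM, the only true number so far. Compound 3 `COc1cc2ncnc(Nc3cccc(Br)c3)c2cc1OCCCCCC(=O)NO` carries a longer chain: 2-(hydroxycarbamoyl)ethyl in place of hydroxycarbamoyl on a saturated chain carbon, three bonds along the chain from an oxygen on an aromatic ring. For the measured compounds named here, the one measured step on this chain is an at least 1.4-fold lower number from compound 1 to compound 2 (0.16 log units; that floor lies within the scatter), so it points only weakly towards lower numbers with added length. A moderate fall in this assay is therefore expected, and the expected step is a 3.4-fold lower number from compound 2 to compound 3 (0.53 log units; beyond the scatter). For compound 3 the estimated value is 20000 nM, with a range of 3000 nM to 100000 nM.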

Compound 3, half-maximal inhibitory concentration: 2800 nM
For compound 3 the middle estimate is 7.1-fold (0.85 log units) above the measured one; measured number outside the range, below it.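

In this assay, among the compounds shown here, the move to 2-(hydroxycarbamoyl)ethyl gives a 24-fold lower number from compound 2 to compound 3 (1.39 log units; beyond the scatter), the first step on this chain that clearly exceeds the scatter. Across all three compounds the change reads an at least 35-fold lower number from compound 1 to compound 3 (1.55 log units; beyond the scatter), so here a longer chain goes with lower numbers, with no compound running against that trend. Compound 1 stands at a limit of the assay and not at a number, so that second step is only a floor: the limit of > 100000 nM in this assay, at which 1 of the 3 values shown sits.

From the compounds shown here alone, it remains open whether a longer chain, such as 5-(hydroxycarbamoyl)pentyl, would lower the number further. Going by these compounds, it is also open whether a carboxylic acid at the chain end, in place of the hydroxycarbamoyl, would behave the same way.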